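A few compounds are considered here, and "the series" means these few. Any claim that something is new, unique, unknown or untested is made for them only; others in the source may bear on it.

Series notes, clearance in an ADME assay (liver) for metabolic stability, with Liver microsome (Rattus norvegicus) as the target, using microsomes and NADPH, with a stated time of 30 min, tested at 1 uM; a higher number here means faster removal of the compound, a lower number slower removal.

The shared core carries a variable aryl group. Compound 1 `Nc1ccc(S(=O)(=O)N2CCN(c3ncc(C(O)(C(F)(F)F)C(F)(F)F)cc3-c3ccoc3)CC2)cn1` gives 57 mL.min-1.g-1 in this assay, the lowest of the three numbers measured. Compound 2 `COc1ccc(-c2cc(C(O)(C(F)(F)F)C(F)(F)F)cnc2N2CCN(S(=O)(=O)c3ccc(N)nc3)CC2)cn1` gives 265 mL.min-1.g-1, and compound 3 `Nc1ccc(S(=O)(=O)N2CCN(c3ncc(C(O)(C(F)(F)F)C(F)(F)F)cc3-c3ccc4ocnc4c3)CC2)cn1` gives 120 mL.min-1.g-1. Both replacements of furan-3-yl raise the number: a 4.6-fold higher number from compound 1 to compound 2 (0.67 log units; beyond the scatter) and a 2.1-fold higher number from compound 1 to compound 3 (0.32 log units; beyond the scatter); between the two alternatives, a 2.2-fold lower number from compound 2 to compound 3 (0.34 log units; beyond the scatter).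

Compound 4 `Nc1ccc(S(=O)(=O)N2CCN(c3ncc(C(O)(C(F)(F)F)C(F)(F)F)cc3-c3cccc4[nH]ncc34)CC2)cn1` is not yet measured in this assay. It differs from compound 1 as follows: 1H-indazol-4-yl in place of furan-3-yl on an aromatic carbon. The two measured steps from compound 1 bear on this one, since each also exchanges furan-3-yl for another aromatic group, and each came out beyond the scatter in the upward direction, the nearer comparison being the 1,3-benzoxazol-5-yl case with a 2.1-fold higher number from compound 1 to compound 3 (0.32 log units; beyond the scatter). A modest rise is therefore expected for compound 4, of about a 2.3-fold higher number from compound 1 to compound 4 (0.36 log units; beyond the scatter), because the measured replacements gave a 2.1-fold higher number from compound 1 to compound 3 (0.32 log units; beyond the scatter) and a 4.6-fold higher number from compound 1 to compound 2 (0.67 log units; beyond the scatter). The estimate for compound 4 in this assay is 130 mL.min-1.g-1, with a range from 60 mL.min-1.g-1 to 300 mL.min-1.g-1.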

Compound 4, intrinsic clearance in microsomes: 93 mL.min-1.g-1
Estimate against measurement, compound 4: 1.4-fold (0.15 log units) above; measured number inside the range.
By their numbers in this assay, from the lowest: compounds 1, 4 and 3 (each within the scatter of the next, the first and the last beyond it); then compound 2.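

In this assay, among these compounds, 1H-indazol-4-yl is the first replacement of furan-3-yl on this aromatic carbon whose step stays within the scatter, with a 1.6-fold higher number from compound 1 to compound 4 (0.21 log units; within the scatter) as the result, so a group with two aromatic rings and a hydrogen-bond donor can stand at this position without a clear change. The step between the two groups with fused rings, a 1.3-fold lower number from compound 3 to compound 4 (0.11 log units; within the scatter), is also within the scatter, whereas a 2.8-fold lower number from compound 2 to compound 4 (0.45 log units; beyond the scatter) leaves compound 2 with the highest number, beyond the scatter of all the others. Nothing available explains these differences.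

As far as these compounds go, how a plain phenyl, or an aryl group carrying an amine or a carboxylic acid, would stand here against compound 1 remains open. So does whether the methoxy group alone sets compound 2 apart, which an unsubstituted pyridin-3-yl would test.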